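Vinyl for Methylsulfonyl on a Scaffold Without Measured Potency

This account rests on a few compounds, and the source may have more. Where it says the series, first, only, none or still open, it means among the compounds named here.

In a functional assay on T-24 cells (Homo sapiens) for cytotoxicity, read by CCK-8 assay, with a stated time of 24 h (on this read-out lower numbers stand for stronger inhibition and higher numbers for weaker inhibition), compound 2 `C/C(=C\c1cc(-c2ccc(S(C)(=O)=O)cc2)cs1)C(N)=O` reaches only the assay limit, > 50000 nM. Compound 1 `C/C(=C\c1nc(-c2ccc(C)cc2)cs1)C(N)=O` likewise stops at the limit, giving > 50000 nM in this assay. For the measured compounds named here, both values sit at the limit of > 50000 nM in this assay, at which 2 of the 2 values shown sit, so compound 2 stands only at a limit, matched by the one other value shown. Compound 3 `C=Cc1ccc(-c2csc(/C=C(\C)C(N)=O)c2)cc1` differs from compound 2 by vinyl in place of methylsulfonyl on an aromatic carbon. Going by the values given here, with no measured step to lean on, compound 3 is expected to show a shift of a number no higher from compound 2 to compound 3 (the limit leaves the size open), none beyond the scatter. Compound 3 is therefore estimated at 50000 nM, within 20000 nM to 120000 nM, most likely again reported only as a limit.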

Compound 3, half-maximal inhibitory concentration: > 50000 nM
Compound 3 gave a limit, no number; the forecaster's own chance of this, stated with the estimate: 80%; the middle value lies on the limit itself.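

Compound 2 and compound 3 both stop at a limit in this assay and so no step can be read for vinyl in place of methylsulfonyl. The compounds shown leave open whether either group changes potency at all.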